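This account rests on a few compounds, and the source may have more. Where it says the series, first, only, none or still open, it means among the compounds named here.

Compound 1 `CCn1cc(-c2nc3ccccc3[nH]2)c(=O)c2cc(F)c(N3CCNCC3)nc21`: 2100 nM
Compound 2 `CCn1cc(-c2nc3ccc([N+](=O)[O-])cc3o2)c(=O)c2cc(F)c(N3CCNCC3)nc21`: 2300 nM

For the measured compounds named here, in a functional assay on AGS cells (Homo sapiens) for cytotoxicity, read by sulforhodamine B assay, with a stated time of 48 h (on this read-out higher numbers stand for weaker inhibition of growth and lower numbers for stronger inhibition of growth), compound 1 and compound 2 lie within the scatter of each other, so compound 1 stands level with the only other measured value. Compound 3 `CCn1cc(-c2nc3ccc(N)cc3[nH]2)c(=O)c2cc(F)c(N3CCNCC3)nc21` differs from compound 1 by amino in place of hydrogen on an aromatic carbon. Going by the values given here, no measured pair shows what this change does, so no step beyond the scatter is expected in this assay, and no direction is firmly expected. The estimated step is a 1.4-fold lower number from compound 1 to compound 3 (0.15 log units; within the scatter). For compound 3 the expected value is 1500 nM, with an estimated range of 500 nM to 4500 nM.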

Compound 3, concentration for 50% growth inhibition: 6700 nM
Estimate against measurement, compound 3: 4.5-fold (0.65 log units) below; measured number above the stated range.
By their numbers in this assay, from the lowest: compounds 1 and 2 (each within the scatter of the next); then compound 3.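

In this assay, for the compounds shown here, amino in place of hydrogen on an aromatic carbon of the six-membered ring of carbon only gives a 3.2-fold higher number from compound 1 to compound 3 (0.50 log units; beyond the scatter) and so the only step beyond the scatter. This position therefore responds to substitution, and in this single pair the change goes with weaker inhibition of growth. No available evidence bears on the reason for this step.

On these data alone, it remains open whether methoxy or chlorine at this position would move the number in the same direction. As far as these compounds go, the size of the step with other groups also remains open.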